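The source may report more compounds than this note shows. Statements on the series, on what has been measured and on what is new or still open speak of the compounds shown alone.

Measured in a functional assay (mast cells) for inhibition, with Rattus norvegicus as the target; a higher number here means that more compound is needed for the effect, a lower number that less compound is needed:
- compound 1 `CC1CCn2c(ncc(C(=O)O)c2=O)/C1=N/Nc1ccccc1`: 5400 nM
- compound 2 `CC1CC/C(=N\Nc2ccc(F)cc2)c2ncc(C(=O)O)c(=O)n21`: 1200 nM
- compound 3 `CCOc1ccc(N/N=C2\CC[C@@H](C)n3c2ncc(C(=O)O)c3=O)cc1`: 1000 nM

Compound 2, at 1200 nM, cannot be told apart from compound 3, while compound 1 needs clearly more material. Compound 4 `Cc1cccc(N/N=C2\CCC(C)n3c2ncc(C(=O)O)c3=O)c1` differs from compound 2 by carrying 3-methylphenyl in place of 4-fluorophenyl on an amine nitrogen. Within the data shown here, no measured pair shows this change alone, so no step beyond the scatter is expected. This rests on compound 2 at 1200 nM and compound 3 at 1000 nM, which carry different groups there yet lie within the scatter of each other. The expected step is a 1.3-fold higher number from compound 2 to compound 4 (0.10 log units; within the scatter). In this assay, compound 4 is estimated at 1500 nM, with a range from 600 nM to 4000 nM.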

Compound 4, half-maximal effective concentration: 72900 nM
For compound 4 the middle estimate is 49-fold (1.69 log units) below the measured one; measured number outside the range, above it.
By their numbers in this assay, from the lowest: compounds 3 and 2 (each within the scatter of the next); then compound 1; then compound 4.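

In this assay, the aryl group on the amine nitrogen can matter greatly: 3-methylphenyl in place of 4-fluorophenyl gives a 61-fold higher number from compound 2 to compound 4 (1.78 log units; beyond the scatter) in a single change. The two groups have the same count of heavy atoms and one aromatic ring each, so those counts alone do not foretell a step of this size. Nothing available here accounts for the step.

From the compounds shown here alone, whether it follows from the methyl, its place on the ring, or the loss of fluorine stays open. A 4-methylphenyl or 3-fluorophenyl group on this nitrogen would separate these possibilities.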